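A few compounds are considered here, and "the series" means these few. Any claim that something is new, unique, unknown or untested is made for them only; others in the source may bear on it.

Two measured compounds share a core and differ only in the aromatic group attached to one carbon of that core. Compound 1, `COc1ccc(-c2nc(C(F)(F)F)ccc2CNC(=O)C(C)c2ccc(NS(C)(=O)=O)c(F)c2)cc1F`, carries a 3-fluoro-4-methoxyphenyl group there, and in an assay on CHO cells for antagonist activity at transient receptor potential cation channel subfamily V member 1 (Homo sapiens), read by FLIPR (a lower number here means a stronger inhibitor, a higher number a weaker inhibitor), compound 1 gives 4.2 nM. Compound 2, `CC(C(=O)NCc1ccc(C(F)(F)F)nc1-c1ccc2cc[nH]c2c1)c1ccc(NS(C)(=O)=O)c(F)c1`, carries a 1H-indol-6-yl group at the same carbon, and in this assay compound 2 gives 20.3 nM. Among the compounds with values here, the single comparison available is a 4.8-fold higher number from compound 1 to compound 2 (0.68 log units; beyond the scatter). Among the two numbers, compound 2 therefore stands at the weaker end, its only neighbour being compound 1.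

Compound 3, `CC(C(=O)NCc1ccc(C(F)(F)F)nc1/C=C/c1ccccc1)c1ccc(NS(C)(=O)=O)c(F)c1`, keeps everything else and changes this same position once more: 2-phenylethenyl in place of 1H-indol-6-yl on an aromatic carbon. Within the data shown here, only one step speaks to this position, and it shows that exchanging the aromatic group shifts the number by a modest amount. Nothing measured tells which way a 2-phenylethenyl group will move it, so a modest shift in either direction is the reasonable expectation, with a slight loss judged a little more likely than a gain since the hydrogen-bond donor of the leaving group is not replaced. Compound 3 is thus expected to give about 30 nM in this assay, with a likely range from 8 nM to 120 nM, an expected step of a 1.5-fold higher number from compound 2 to compound 3 (0.17 log units; within the scatter).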

Compound 3, inhibition constant: 2.2 nM
Beside the measured number, compound 3's estimate is 14-fold (1.13 log units) above it; the whole stated range lies above it.
By their numbers in this assay, from the lowest: compounds 3 and 1 (each within the scatter of the next); then compound 2.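

Within the data shown here, the result shows that this position does not simply penalise a change of aromatic group: in this assay, a 9.2-fold lower number from compound 2 to compound 3 (0.97 log units; beyond the scatter) is a larger move than the one step seen so far, and it runs the opposite way, so the 1H-indol-6-yl group now stands out as the weakest of the three. A low number also does not depend on the hydrogen-bond donor of the 1H-indol-6-yl group, and it does not need an aromatic ring attached directly to the core, as the 2-phenylethenyl group has no such donor and places a double bond outside its aromatic ring. The comparison with the other good group gives a 1.9-fold lower number from compound 1 to compound 3 (0.28 log units; within the scatter), so two quite different groups cannot be told apart here, and nothing measured explains why the 1H-indol-6-yl group stands apart from them.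

On these data alone, it remains open whether the double bond itself matters, which a saturated 2-phenylethyl group would test. As far as these compounds go, it is also open how this position would respond to a plain phenyl group or to a group carrying an amine.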